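A few compounds are considered here, and "the series" means these few. Any claim that something is new, unique, unknown or untested is made for them only; others in the source may bear on it.

In a functional assay on A549 cells (Homo sapiens) for cytotoxicity, read by MTT assay, with a stated time of 48 h (a higher number here means a weaker inhibitor, a lower number a stronger inhibitor), three compounds built on the shared core of compound 1 `CCN(CC)c1ccc2cc(C(=O)c3ccc(N4CCN(C(=O)COc5ccc(Cl)cc5Cl)CC4)cc3)oc2c1` differ only in the group carried by the ring nitrogen of the piperazine. Compound 1 gives 5730 nM. Compound 3 `CCN(CC)c1ccc2cc(C(=O)c3ccc(N4CCN(S(=O)(=O)c5ccc(C(F)(F)F)cc5)CC4)cc3)oc2c1` gives 11100 nM. Compound 2 `CCOC(=O)N1CCN(c2ccc(C(=O)c3cc4ccc(N(CC)CC)cc4o3)cc2)CC1` gives in this assay no number but a limit, > 40000 nM. The step of an at least 6.9-fold higher number from compound 1 to compound 2 (0.84 log units; beyond the scatter) is therefore known only as a floor, because of the limit of > 40000 nM in this assay, at which 1 of the 3 values shown sits. Compound 2 thus stands at the weak end of the three values shown, beyond the reach of the assay.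

Compound 4 `CCN(CC)c1ccc2cc(C(=O)c3ccc(N4CCN(C(C)=O)CC4)cc3)oc2c1` differs from compound 2 by methyl in place of ethoxy on a carbonyl carbon. Within the data shown here, only one measured step concerns this carbonyl carbon: the loss of the (2,4-dichlorophenoxy)methyl group cost at least a modest amount, and the sulfonyl replacement in compound 3 also sits well above compound 1. A further trimming to a methyl gives compound 4 no larger group than compound 2 has, so no recovery toward compound 1 is foreseen; a step within the scatter, or none that the assay can resolve, is the expectation.

Compound 4 is therefore expected to give around 45000 nM, within the range 15000 nM to 150000 nM. The estimated step that the limit leaves unreadable from compound 2 to compound 4 is accordingly expected to stay within the scatter, with a fair chance that only a limit is again reported.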

Compound 4, half-maximal inhibitory concentration: 30100 nM
Estimate against measurement, compound 4: 1.5-fold (0.17 log units) above, within the range that was stated.
By their numbers in this assay, from the lowest: compounds 1 and 3 (each within the scatter of the next); then compound 4. At a limit, above all of these: compound 2.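

With methyl in place of ethoxy on this carbonyl carbon, compound 4 gives a number in this assay where compound 2 gave only a limit, but the change can be sized only as a floor: an at least 1.3-fold lower number from compound 2 to compound 4 (0.12 log units; that floor lies within the scatter). That floor cannot show how far apart the two compounds really lie, because compound 2 has no number of its own: the limit of > 40000 nM in this assay, at which 1 of the 4 values shown sits. Among these compounds, the firmer new reading concerns the chain on the carbonyl carbon, where hydrogen in place of 2,4-dichlorophenoxy gives the loss an actual size for the first time, a 5.3-fold higher number from compound 1 to compound 4 (0.72 log units; beyond the scatter), whereas the earlier step from the same compound to the ethoxycarbonyl group had only a lower bound.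

The compounds shown leave open whether that loss follows the chlorine atoms, the phenoxy ring or simply the length of the group on the carbonyl carbon. A plain phenoxy on the same chain, or a longer alkyl chain or an amine in its place, would be needed to tell these apart in this assay.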